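Hydroxyphenyl for fluorophenyl on the triazole nitrogen

The source may hold more compounds than are shown below. What is called first, only, known or untested is meant among the compounds shown, and "the series" means these compounds.

Compound 1 `CC1(C)[C@H]2CC[C@]1(C)N(Cc1cn(-c3cccc(F)c3)nn1)C(=O)C2`: 180 nM
Compound 2 `CC1(C)[C@H]2CC[C@]1(C)N(Cc1cn(-c3ccc(O)cc3)nn1)C(=O)C2`: 140 nM

Among the compounds with values here, in a functional assay on A549 cells (Homo sapiens) for inhibition, read by MTT assay, with a stated time of 24 h (a higher number here means a weaker inhibitor, a lower number a stronger inhibitor), compound 1 gives 180 nM, the highest of the two numbers so far; compound 2 gives 140 nM, and the step of a 1.3-fold lower number from compound 1 to compound 2 (0.11 log units; within the scatter) lies within the scatter. Compound 3 `CC1(C)[C@H]2CC[C@]1(C)N(Cc1cn(-c3ccccc3O)nn1)C(=O)C2` is not yet measured. It differs from compound 1 as follows: 2-hydroxyphenyl in place of 3-fluorophenyl on an aromatic nitrogen. Within the data shown here, the only measured step that bears on this is the one from compound 1 to compound 2, a hydroxyphenyl also entering for the 3-fluorophenyl, and it was small. The expected step is therefore a 1.1-fold lower number from compound 1 to compound 3 (0.02 log units; within the scatter), nothing beyond the scatter. Compound 3 is estimated at 170 nM, with a range from 70 nM to 420 nM.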

Compound 3, half-maximal inhibitory concentration: 230 nM
Estimate against measurement, compound 3: 1.4-fold (0.13 log units) below; the measured number falls inside the stated range.
By their numbers in this assay, from the lowest: compounds 2, 1 and 3 (each within the scatter of the next).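

In this assay, the 2-hydroxyphenyl group on the aromatic nitrogen gives a 1.3-fold higher number from compound 1 to compound 3 (0.11 log units; within the scatter) and a 1.6-fold higher number from compound 2 to compound 3 (0.22 log units; within the scatter). The numbers therefore separate neither 2-hydroxyphenyl from 4-hydroxyphenyl nor either of them from 3-fluorophenyl, so where the hydroxyl stands on the phenyl ring makes no readable difference at this position. From the compounds shown here alone, what remains open is whether an amine or a carboxylic acid on that phenyl ring, or a longer chain in its place, would give a step beyond the scatter. No available evidence explains these numbers.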